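The source may hold more compounds than are shown below. What is called first, only, known or untested is meant among the compounds shown, and "the series" means these compounds.

Compound 1 `Cc1nc(N)sc1CCCN/C(N)=N/C(=O)NC1CCCCC1` carries a cyclohexyl group on the urea nitrogen at the end of its acylguanidine chain. In a functional assay on membranes from Sf9 cells for agonist activity at histamine H2 receptor (Homo sapiens), read by scintillation counting and GTPgammaS binding, with a stated time of 90 min (on this read-out lower numbers stand for an effect already at smaller amounts and higher numbers for an effect only at larger amounts of compound), compound 1 gives 148 nM. Among the compounds with values here, the only other compound measured here, compound 2 `N/C(=N\C(=O)NCc1ccccc1)NC1CCc2nc(N)sc2C1`, is built on a different core and carries a benzyl group in the corresponding place; in this assay compound 2 gives 214 nM. The gap between these two numbers lies within the usual scatter of the measurement, so neither compound can be placed ahead of the other on this read-out.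

Compound 3 `Cc1nc(N)sc1CCCN/C(N)=N/C(=O)NCc1ccccc1` keeps the core of compound 1 and differs from it by benzyl in place of cyclohexyl on an amide-type nitrogen. Within the data shown here, no directly comparable pair has been measured, so the size of this step is unknown. Since compound 2, which carries the same benzyl group, gives 214 nM close to compound 1 at 148 nM, the step of a 1.4-fold higher number from compound 1 to compound 3 (0.13 log units; within the scatter) is expected to stay within the scatter. Compound 3 is therefore estimated at 200 nM, with a likely range from 70 nM to 600 nM.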

Compound 3, half-maximal effective concentration: 28.8 nM
Beside the measured number, compound 3's estimate is 6.9-fold (0.84 log units) above it; the measured number lies below the stated range.
By their numbers in this assay, from the lowest: compound 3; then compounds 1 and 2 (each within the scatter of the next).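

On an amide-type nitrogen, with the core of compound 1 held fixed, benzyl in place of cyclohexyl gives a 5.1-fold lower number from compound 1 to compound 3 (0.71 log units; beyond the scatter) in this assay. Within the data shown here, this is the first reading of this position on its own, and it shows that the number responds to the group placed there, which the two earlier compounds could not show, as they differ in more than one place. Nothing measured here bears on why the number moves.

The compounds shown leave open whether the lower number follows the aromatic ring or the additional carbon atom of benzyl, two features that a cyclohexylmethyl group on the same nitrogen would separate. Also open, from the compounds shown here alone, is how a phenylethyl group, with its longer chain, or a methoxy group on the benzyl ring would read in this assay.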